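A few compounds are considered here, and "the series" means these few. Any claim that something is new, unique, unknown or untested is made for them only; others in the source may bear on it.

Working notes on the series. Compound 1 `COc1cc(F)ccc1N1CCN(CCCNc2c(C(=O)N(C)C)cnc3c(C(N)=O)cccc23)CC1` in a functional assay on aorta for antagonist activity at Alpha-1D adrenergic receptor (Rattus norvegicus) (on this read-out higher numbers stand for weaker binding and lower numbers for tighter binding), gives 158 nM. Compound 2 `COc1cc(F)ccc1N1CCN(CCCNc2c(C(=O)N(C)C)cnc3c2c(C)nn3C)CC1` in this assay gives 316 nM; the two numbers sit within the scatter of each other, so nothing separates them. For the measured compounds named here, no pair of measured compounds differs in a single place, so no step size is known. Compound 3 `Cc1nn(C)c2ncc(C(=O)N(C)C)c(NCCCN3CCN(c4ccc(F)cc4-c4ncco4)CC3)c12` carries the change (1,3-oxazol-2-yl in place of methoxy on an aromatic carbon). The step of a 1.3-fold higher number from compound 2 to compound 3 (0.10 log units; within the scatter) is an expectation only, a small rise and little beyond the scatter. For compound 3 in this assay the estimate is 400 nM, in the range 130 nM to 1300 nM.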

Compound 3, dissociation constant: 200 nM
The estimate for compound 3 lay 2.0-fold (0.30 log units) above the measured number; the measured number falls inside the stated range.
By their numbers in this assay, from the lowest: compounds 1, 3 and 2 (each within the scatter of the next).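

For the compounds shown here, this is the first single-place step: in this assay, 1,3-oxazol-2-yl in place of methoxy gives a 1.6-fold lower number from compound 2 to compound 3 (0.20 log units; within the scatter). The aromatic carbon ortho to a large group and meta to the fluoro group therefore accepts a five-membered aromatic ring in place of the methoxy group, with no shift beyond the scatter. Nothing available here speaks to the reason for this result. Still open, as far as these compounds go, is whether an amine or a carboxylic acid at this carbon would read the same, and whether the same change would hold on the core of compound 1.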